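Chloroaryl amides: phenyl to chloropyridyl on the amide nitrogen

The source may report more compounds than this note shows. Statements on the series, on what has been measured and on what is new or still open speak of the compounds shown alone.

Compound 1 `Cc1noc(C)c1-c1cnc(N)c(Oc2ccc(C(=O)Nc3ccccc3Cl)cc2)n1`, compound 2 `Cc1noc(C)c1-c1cnc(N)c(Oc2ccc(C(=O)Nc3ccc(Cl)cc3)cc2)n1` and compound 3 `Cc1noc(C)c1-c1cnc(N)c(Oc2ccc(C(=O)Nc3cccc(Cl)c3)cc2)n1` share one core and differ only in the chlorophenyl on the amide nitrogen. In a functional assay on LoVo cells (Homo sapiens) for inhibition, read by MTT assay, with a stated time of 72 h (a higher number here means a weaker inhibitor, a lower number a stronger inhibitor), compound 1 gives only a limit, > 100000 nM, which is the limit of > 100000 nM in this assay, at which 1 of the 3 values shown sits. Compound 2 gives 1920 nM and compound 3 gives 1640 nM. The recorded steps are an at least 52-fold lower number from compound 1 to compound 2 (1.71 log units; beyond the scatter) and an at least 60-fold lower number from compound 1 to compound 3 (1.78 log units; beyond the scatter), whereas a 1.2-fold lower number from compound 2 to compound 3 (0.07 log units; within the scatter). Among the two numbers shown, compound 3 holds the lower one, with compound 2 within the scatter of it.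

Compound 4 `Cc1noc(C)c1-c1cnc(N)c(Oc2ccc(C(=O)Nc3cccc(Cl)n3)cc2)n1` carries 6-chloropyridin-2-yl in place of 3-chlorophenyl on an amide-type nitrogen. Among the compounds with values here, no measured step exchanges a ring carbon for a ring nitrogen, so this part of the change is untested here. Within the data shown here, the step that bears on it most is the one between compound 2 and compound 3, which shows that exchanging 4-chlorophenyl for 3-chlorophenyl changed little; the large steps from compound 1 concern the 2-chlorophenyl and do not carry over. Compound 4 is therefore expected near compound 3, at 2000 nM, within 700 nM to 6000 nM. The step expected is a 1.2-fold higher number from compound 3 to compound 4 (0.09 log units; within the scatter), none beyond the scatter.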

Compound 4, half-maximal inhibitory concentration: 39300 nM
Beside the measured number, compound 4's estimate is 20-fold (1.29 log units) below it; the whole stated range lies below it.
By their numbers in this assay, from the lowest: compounds 3 and 2 (each within the scatter of the next); then compound 4. At a limit, above all of these: compound 1.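

The amide-nitrogen substituent proved sensitive to more than chlorine placement: in this assay, a ring nitrogen in the chlorinated aryl group brought a large loss that the near-equal 3-chlorophenyl and 4-chlorophenyl amides did not foreshadow, with a 24-fold higher number from compound 3 to compound 4 (1.38 log units; beyond the scatter) and a 20-fold higher number from compound 2 to compound 4 (1.31 log units; beyond the scatter). The 6-chloropyridin-2-yl amide still stays apart from the 2-chlorophenyl amide, with an at least 2.5-fold lower number from compound 1 to compound 4 (0.40 log units; beyond the scatter). The entry for compound 1 is a limit and not a number: the limit of > 100000 nM in this assay, at which 1 of the 4 values shown sits.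

On these data alone, whether the loss follows from the ring nitrogen alone or from its combination with the chlorine remains open. Also open, as far as these compounds go, is how a pyridin-2-yl group without chlorine, or a 6-methoxypyridin-2-yl group, would read in this assay.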